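A few compounds are considered here, and "the series" means these few. Any claim that something is new, unique, unknown or untested is made for them only; others in the source may bear on it.

Measured in a functional assay on the whole organism (artery, strain albino) with Rattus norvegicus as the target, with a stated time of 180 min, at a dose of 10 mg/kg by the oral route; a higher number here means more inhibition at the dose given (going by the name of the read-out), a lower number less inhibition:

Compound 1, `CC1=C(C(=O)Nc2ccc(F)cc2)C(c2ccc([N+](=O)[O-])cc2)N=C(SCc2ccccc2Cl)N1`: 12.4%
Compound 2, `CC1=C(C(=O)Nc2ccc(F)cc2)C(c2ccc([N+](=O)[O-])cc2)N=C(SCc2cccc(Cl)c2)N1`: 11.9%
Compound 3, `COc1ccc(C2N=C(SCc3ccccc3Cl)NC(C)=C2C(=O)Nc2ccc(Br)cc2)cc1`: 11.3%

All three numbers sit close together in this assay. Compound 1 and compound 2 share one core and differ by 3-chlorophenyl in place of 2-chlorophenyl on a saturated chain carbon bound to a sulfur; that change gave a number 0.5 percentage points lower from compound 1 to compound 2 (within the scatter). Compound 3 carries a different core, and the difference between the two cores is not broken down here. Compound 4, `COc1ccc(C2N=C(SCc3cccc(Cl)c3)NC(C)=C2C(=O)Nc2ccc(Br)cc2)cc1`, has not yet been measured; it differs from compound 3 by 3-chlorophenyl in place of 2-chlorophenyl on a saturated chain carbon bound to a sulfur, the same change at the same place as between compound 1 and compound 2. Resting on the small step seen in a number 0.5 percentage points lower from compound 1 to compound 2 (within the scatter), the step from compound 3 to compound 4 is expected to be about as small, a number 0.5 percentage points lower from compound 3 to compound 4 (within the scatter). For compound 4 the estimate in this assay is 10.8%, expected to fall between 3% and 19%.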

Compound 4, a percentage reported as inhibition, in the whole organism at one dose (the size of the read-out at that dose, not a potency): 27.3%
Beside the measured number, compound 4's estimate is 16.5 percentage points below it; measured number outside the range, above it.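

In this assay, 3-chlorophenyl in place of 2-chlorophenyl gave a number 16 percentage points higher from compound 3 to compound 4 (beyond the scatter). The effect of this change therefore did not carry over from one core to the other: the same change on two cores in this assay, a number 0.5 percentage points lower (within the scatter) from compound 1 to compound 2 and a number 16 percentage points higher (beyond the scatter) from compound 3 to compound 4, 16.5 percentage points apart, beyond the scatter of two such steps

For the compounds shown here, this shows that a step measured on one core is a poor guide to the same step on the other, but with only one pair on each core, it does not show which difference between the cores matters or why. Still open, as far as these compounds go, is which part of the core decides the size of the step, and whether it would also appear with a plain benzyl group or a longer alkyl chain on the sulfur.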